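The source may report more compounds than this note shows. Statements on the series, on what has been measured and on what is new or still open speak of the compounds shown alone.

Measured in a functional assay (aorta) with Oryctolagus cuniculus as the target; a higher number here means weaker binding, a lower number tighter binding:
- compound 1 `COc1cc(C(C)=O)ccc1OCCCN1CCC(C(c2ccc(F)cc2)c2ccc(F)c(F)c2)CC1`: 1.26 nM
- compound 2 `COc1cc(C(C)=O)ccc1OCCCN1CCC(C(c2ccc(F)c(F)c2)c2ccc(F)c(F)c2)CC1`: 2.51 nM

Among the compounds with values here, these are the only two numbers so far, and they lie within the usual scatter of each other, so compound 1 cannot be ranked against compound 2. Compound 1 serves as the starting point for compound 3 `COc1cc(C(C)=O)ccc1OCCCN1CCC(Cc2ccc(F)cc2)CC1`, which has not yet been measured.

The change is hydrogen in place of 3,4-difluorophenyl on a saturated chain carbon bound to an aromatic carbon and a saturated ring carbon. In words, hydrogen stands in place of 3,4-difluorophenyl on a saturated chain carbon bound to an aromatic carbon and a saturated ring carbon.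

Within the data shown here, only one measured step bears on this: a 2.0-fold higher number from compound 1 to compound 2 (0.30 log units; within the scatter). That step puts fluoro in place of hydrogen on an aromatic carbon, so it shows only that this small edit stays within the scatter. Among the measured compounds shown here, no measured compound lacks the whole ring, so the data give no direct guide to this much larger change. A real shift in this assay is therefore expected, more likely towards a higher number, though this is a judgement with wide uncertainty. The expected step is a 6.3-fold higher number from compound 1 to compound 3 (0.80 log units; beyond the scatter). For compound 3 the estimated value is 8 nM, with a range of 2 nM to 32 nM.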

Compound 3, dissociation constant: 20 nM
Compound 3: middle estimate off by 2.5-fold (0.40 log units), on the low side; low and high end bracket the measured number.
By their numbers in this assay, from the lowest: compounds 1 and 2 (each within the scatter of the next); then compound 3.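

In this assay, putting hydrogen in place of the 3,4-difluorophenyl on the saturated chain carbon bound to an aromatic carbon and a saturated ring carbon gives a 16-fold higher number from compound 1 to compound 3 (1.20 log units; beyond the scatter), a step well beyond the scatter. The earlier pair differed only by one fluoro on an aromatic carbon and stayed within the scatter, so it could not show whether this position responds to change at all; this pair shows that removing the whole 3,4-difluorophenyl matters far more than that single fluoro, and that compound 3 binds more weakly than compound 1. No measurement at hand explains this loss of binding.

The compounds shown leave open how much of the ring is needed at this carbon: a plain phenyl without any fluoro, or just a methyl, could sit anywhere from close to compound 1 to close to compound 3. Also open, on these data alone, is whether a hydroxyl on this carbon would read more like the hydrogen or more like the ring.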